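Chloro for bromo: expected outcome for compound 3

A few compounds are considered here, and "the series" means these few. Any claim that something is new, unique, unknown or untested is made for them only; others in the source may bear on it.

Measured so far:
compound 1, `Brc1ccccc1/C=N/c1nc2ccccc2[nH]1`, 26.3 uM
compound 2, `COc1cc(/C=N/c2nc3ccccc3[nH]2)cc(OC)c1OC`, 50.4 uM

In a functional assay on SW707 cells (Homo sapiens) for antiproliferative activity, read by sulforhodamine B assay, with a stated time of 72 h (a higher number here means a weaker inhibitor, a lower number a stronger inhibitor), compound 1 gives 26.3 uM and compound 2 gives 50.4 uM. The two numbers lie within the scatter of each other, so neither compound is set apart from the other in this assay; compound 1 merely carries the number at the low end of this pair.

Compound 3, `Clc1ccccc1/C=N/c1nc2ccccc2[nH]1`, is still to be measured. It differs from compound 1 by chloro in place of bromo on an aromatic carbon. Going by the values given here, no measured pair shows a swap of this kind, so nothing measured here tells its direction. An exchange of one halogen for another at the same place is expected to move the number little; the step of a 1.1-fold higher number from compound 1 to compound 3 (0.06 log units; within the scatter) is estimated to stay within the scatter. Compound 3 is therefore expected to give about 30 uM, with a range from 12 uM to 75 uM.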

Compound 3, concentration for 50% inhibition: 63.4 uM
For compound 3 the middle estimate is 2.1-fold (0.32 log units) below the measured one; the measured number falls inside the stated range.
By their numbers in this assay, from the lowest: compounds 1, 2 and 3 (each within the scatter of the next, the first and the last beyond it).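

Going by these compounds alone, this is the first step that changes a single place, and it shows that the halogen on this aromatic carbon, ortho to a large group, is not interchangeable: in this assay, chloro in place of bromo gives a 2.4-fold higher number from compound 1 to compound 3 (0.38 log units; beyond the scatter). The step is modest, but it places bromo ahead of chloro at this position, a reading that the pair of compound 1 and compound 2, which differ in more than one place, could not give. Nothing available accounts for this difference between the two halogens.

Going by these compounds, whether fluoro or iodo at the same place would extend this order remains open, as does how an amine or a carboxylic acid would fare there. A single pair also leaves open whether the same swap at another carbon of this ring would give a step of similar size.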